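The compounds below may be only part of what the source reports. "The series", "measured", "known", "first", "only" and "open" are said of these compounds alone.

Measured in a functional assay on MDA-MB-231 cells (Homo sapiens) for inhibition, read by CellTiter-Glo, with a stated time of 72 h; on this read-out higher numbers stand for lower toxicity in this test and lower numbers for higher toxicity in this test:
- compound 1 `CC1=C(CC(=O)NCCN(C)C)c2cc(F)ccc2/C1=C\c1ccncc1`: 18100 nM
- compound 2 `CC1=C(CC(=O)NCCN2CCCC2)c2cc(F)ccc2/C1=C\c1nc2ccccc2s1`: 3560 nM
- compound 3 `CC1=C(CC(=O)N2CCN(c3ccncc3)CC2)c2cc(F)ccc2/C1=C\c1nc2ccccc2s1`: 7710 nM

Compound 2 has the lowest number of the three. Compound 4 `CC1=C(CC(=O)NCCN2CCCC2)c2cc(F)ccc2/C1=C\c1ccncc1` carries pyridin-4-yl in place of 1,3-benzothiazol-2-yl on a double-bonded chain carbon bound to a double-bonded ring carbon. Going by the values given here, the only measured step, a 2.2-fold higher number from compound 2 to compound 3 (0.34 log units; beyond the scatter), is a modest one on a carbonyl carbon, a different place, so it bears on this change only indirectly. Sharing pyridin-4-yl with compound 4, compound 1 gives 18100 nM, but it also differs from compound 4 in its amide chain. A moderate rise in this assay is therefore expected, beyond the scatter: a 3.1-fold higher number from compound 2 to compound 4 (0.49 log units; beyond the scatter). The estimate for compound 4 is 11000 nM, with an expected range from 4500 nM to 25000 nM.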

Compound 4, half-maximal cytotoxic concentration: 7190 nM
Beside the measured number, compound 4's estimate is 1.5-fold (0.18 log units) above it, within the range that was stated.
By their numbers in this assay, from the lowest: compound 2; then compounds 4 and 3 (each within the scatter of the next); then compound 1.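

In this assay, going by these compounds alone, pyridin-4-yl in place of 1,3-benzothiazol-2-yl on a double-bonded chain carbon bound to a double-bonded ring carbon gives a 2.0-fold higher number from compound 2 to compound 4 (0.31 log units; beyond the scatter) with the amide chain unchanged, the first direct reading of this place. Compound 4 also isolates the amine end of that chain: pyrrolidin-1-yl in place of dimethylamino gives a 2.5-fold lower number from compound 1 to compound 4 (0.40 log units; beyond the scatter) with pyridin-4-yl held constant. No measurement shown explains either step.

From the compounds shown here alone, whether a plain phenyl or a pyridin-3-yl at the first place would give numbers nearer compound 2 or compound 4 remains open. So does the effect of a piperidine or morpholine at the chain end.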